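The compounds below may be only part of what the source reports. "The series", "measured", "known", "first", "only" and "open" are said of these compounds alone.

In a functional assay on HL-60 cells (Homo sapiens) for cytotoxicity, read by WST assay, with a stated time of 48 h (on this read-out higher numbers stand for an effect only at larger amounts of compound and lower numbers for an effect already at smaller amounts), three compounds with a shared core differ only in the group on an oxygen on an aromatic ring. Compound 1 (`O=C1OC[C@H](Cc2ccccc2)[C@H]1Cc1ccc(OC(F)(F)F)cc1`) gives 27000 nM, compound 2 (`COCOc1ccc(C[C@H]2C(=O)OC[C@@H]2Cc2ccccc2)cc1`) gives 71000 nM and compound 3 (`CCCCOc1ccc(C[C@H]2C(=O)OC[C@@H]2Cc2ccccc2)cc1`), which carries butyl there, gives 23000 nM. Compound 3 therefore stands level with compound 1 and under compound 2. Compound 4 (`CCCCCCCOc1ccc(C[C@H]2C(=O)OC[C@@H]2Cc2ccccc2)cc1`) extends that butyl chain, with propyl in place of hydrogen on a saturated chain carbon, four bonds along the chain from an oxygen on an aromatic ring.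

Among the compounds with values here, two measured steps bear on this change. Butyl in place of methoxymethyl gave a 3.1-fold lower number from compound 2 to compound 3 (0.49 log units; beyond the scatter), a modest move to a lower number, whereas butyl in place of trifluoromethyl gave a 1.2-fold lower number from compound 1 to compound 3 (0.07 log units; within the scatter). On these data alone, no chain longer than butyl has been measured, so the trend remains open. A small move towards a lower number is expected, probably not clearly beyond the scatter: a 1.6-fold lower number from compound 3 to compound 4 (0.22 log units; within the scatter). For compound 4 the estimated value is 14000 nM, with an expected range from 5000 nM to 40000 nM.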

Compound 4, half-maximal effective concentration: > 100000 nM
Compound 4: a limit, no number (the forecaster's own chance of this, stated with the estimate: 10%); at least 7.1-fold (0.85 log units) between middle value and limit.
By their numbers in this assay, from the lowest: compounds 3 and 1 (each within the scatter of the next); then compound 2. At a limit, above all of these: compound 4.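

In this assay compound 4 gives > 100000 nM, which is a limit of the assay and not a number. The earlier compounds shown here showed butyl on this oxygen sitting level with trifluoromethyl and under methoxymethyl, but they could not show that this position has a limit on chain length; propyl in place of hydrogen, four bonds along the chain from the oxygen, gives an at least 4.3-fold higher number from compound 3 to compound 4 (0.63 log units; beyond the scatter). The heptyl chain also gives an at least 3.7-fold higher number from compound 1 to compound 4 (0.56 log units; beyond the scatter), while an at least 1.4-fold higher number from compound 2 to compound 4 (0.14 log units; that floor lies within the scatter) leaves compound 2 and compound 4 without a firm order.

On these data alone, whether the number climbs gradually or abruptly between butyl and heptyl stays open, and pentyl and hexyl on this oxygen would settle that. Also open, as far as these compounds go, is how a butyl chain ending in an amine or a carboxylic acid would behave here.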